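Aryl Exchange on the Triazole Nitrogen: Compound 3 Awaited

A few compounds are considered here, and "the series" means these few. Any claim that something is new, unique, unknown or untested is made for them only; others in the source may bear on it.

Measured compounds:
Compound 1 `Cc1cccc(-n2nncc2CN2C(=O)C3(C(C#N)=C(N)Oc4c(N)cc5nc6ccccc6nc5c43)c3ccccc32)c1`: 12300 nM
Compound 2 `CCc1ccccc1-n1nncc1CN1C(=O)C2(C(C#N)=C(N)Oc3c(N)cc4nc5ccccc5nc4c32)c2ccccc21`: 24600 nM

In a functional assay on A549 cells (Homo sapiens) for antiproliferative activity, read by MTT assay, with a stated time of 48 h (on this read-out higher numbers stand for weaker inhibition and lower numbers for stronger inhibition), compound 2 gives the highest of the two numbers; its nearest neighbour is compound 1, and the step of a 2.0-fold higher number from compound 1 to compound 2 (0.30 log units; within the scatter) lies within the scatter. Compound 3 `N#CC1=C(N)Oc2c(N)cc3nc4ccccc4nc3c2C12C(=O)N(Cc1cnnn1-c1ccc(Cl)cc1)c1ccccc12` differs from compound 2 by 4-chlorophenyl in place of 2-ethylphenyl on an aromatic nitrogen. Among the measured compounds shown here, the only measured step that bears on this position is the one from compound 1 to compound 2, which exchanged one aryl group for another on the same aromatic nitrogen without moving the number beyond the scatter. For the measured compounds named here, no measured compound carries a chlorine-bearing aryl group, so nothing in the set speaks for a shift in either direction. The step of a 1.4-fold lower number from compound 2 to compound 3 (0.16 log units; within the scatter) is therefore expected to stay within the scatter. For compound 3 the estimated value in this assay is 17000 nM, within a range from 6000 nM to 50000 nM.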

Compound 3, half-maximal inhibitory concentration: > 50000 nM
Compound 3 was reported as a limit (the forecaster's own chance of this, stated with the estimate: 10%); at least 2.9-fold (0.46 log units) between middle value and limit.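

Compound 3 is reported in this assay as a limit, not as a number: the limit of > 50000 nM in this assay, at which 1 of the 3 values shown sits. Among the compounds shown here, the exchange of 3-methylphenyl for 4-chlorophenyl on the aromatic nitrogen gives an at least 4.0-fold higher number from compound 1 to compound 3 (0.60 log units; beyond the scatter), the first step at this position that lies beyond the scatter, so the choice of aryl group here can change the read-out. The exchange of 2-ethylphenyl for 4-chlorophenyl gives an at least 2.0-fold higher number from compound 2 to compound 3 (0.30 log units; that floor lies within the scatter), and only the floor of that step is known.

The compounds shown do not separate the chlorine from its place on the ring: a 3-chlorophenyl or a 4-methylphenyl group stands outside the set. Nor do they say how a group without an aromatic ring, such as a short alkyl chain or an amine, would read on this nitrogen.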